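The source may report more compounds than this note shows. Statements on the series, on what has been measured and on what is new or still open speak of the compounds shown alone.

Measured compounds:
compound 1 `CCCC(C)n1c(N2CCN(C)CC2)nc2ccccc21` — 1400 nM
compound 2 `CN1CCN(c2nc3ccccc3n2-c2ccccc2)CC1` — 760 nM
compound 3 `CCSCCCn1c(N2CCN(C)CC2)nc2ccccc21` — 530 nM

In a functional assay on ileum for inhibition of histamine H1 receptor (Cavia porcellus) (a lower number here means a stronger inhibitor, a higher number a weaker inhibitor), compound 3 gives the smallest of the three numbers; against compound 1 the step is a 2.6-fold lower number from compound 1 to compound 3 (0.42 log units; beyond the scatter), against compound 2 only a 1.4-fold lower number from compound 2 to compound 3 (0.16 log units; within the scatter), so compound 2 and compound 3 are not separated. Compound 4 `CCSCCn1c(N2CCN(C)CC2)nc2ccccc21` differs from compound 3 by ethylsulfanyl in place of (ethylsulfanyl)methyl on a saturated chain carbon, two bonds along the chain from an aromatic nitrogen. Among the measured compounds shown here, no measured step shortens the chain in this way; the three steps exchange the whole substituent on the aromatic nitrogen, a 1.8-fold lower number from compound 1 to compound 2 (0.27 log units; within the scatter), a 2.6-fold lower number from compound 1 to compound 3 (0.42 log units; beyond the scatter) and a 1.4-fold lower number from compound 2 to compound 3 (0.16 log units; within the scatter), and stay modest or within the scatter. A step within the scatter is therefore expected, if anything towards a higher number. Compound 4 is expected near 700 nM, between 300 nM and 1600 nM, a step of a 1.3-fold higher number from compound 3 to compound 4 (0.12 log units; within the scatter).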

Compound 4, half-maximal inhibitory concentration: 19 nM
Compound 4: the middle estimate sits 37-fold (1.57 log units) above what was measured, and the stated range ends above it.
By their numbers in this assay, from the lowest: compound 4; then compounds 3, 2 and 1 (each within the scatter of the next, the first and the last beyond it).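

In this assay the length of the chain on the aromatic nitrogen proves decisive: 2-(ethylsulfanyl)ethyl in place of 3-(ethylsulfanyl)propyl gives a 28-fold lower number from compound 3 to compound 4 (1.45 log units; beyond the scatter) and so exceeds every earlier step. The same group also stands clear of the other substituents, with a 40-fold lower number from compound 2 to compound 4 (1.60 log units; beyond the scatter) against phenyl and a 74-fold lower number from compound 1 to compound 4 (1.87 log units; beyond the scatter) against 1-methylbutyl. No evidence at hand bears on the size of these steps.

Open, from the compounds shown here alone, is whether the sulfur is needed at this chain length, as an ether oxygen or a plain butyl chain would show. Also open, going by these compounds, is how the shorter (ethylsulfanyl)methyl chain behaves.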